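The source may report more compounds than this note shows. Statements on the series, on what has been measured and on what is new or still open speak of the compounds shown alone.

Measured so far in a functional assay on HT-29 cells (Homo sapiens) for antiproliferative activity, read by MTT assay, with a stated time of 72 h; a higher number here means a weaker inhibitor of growth, a lower number a stronger inhibitor of growth:

Compound 1 `CNc1ccc(-c2cn3c(OC)cc(OC)nc3n2)cc1` gives > 100000 nM in this assay, a limit of the assay and not a number.
Compound 2 `Cc1ccc2nc(-c3ccc(NCc4ccccc4)cc3)cn2c1` gives 8800 nM in this assay.
Compound 3 `Cc1ccn2cc(-c3ccc([N+](=O)[O-])cc3)nc2c1` gives > 100000 nM in this assay, again a limit of the assay rather than a measured number.

Compound 3 therefore stands at the edge of what this assay can report, and it shares that position with one of the other two compounds (the limit of > 100000 nM in this assay, at which 2 of the 3 values shown sit). Only compound 2 yields a number at all.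

Compound 4 `Cc1ccn2cc(-c3ccc(N)cc3)nc2c1` is not yet measured. It differs from compound 3 in one place: amino in place of nitro on an aromatic carbon. Within the data shown here, no pair among the measured compounds differs by this single change, so there is no measured step to lean on. What the measured compounds show is that an amine bearing a methyl on the nitrogen, in compound 1, also sits at the limit, while only the benzyl-bearing amine of compound 2 reaches a number.

On that basis compound 4 is expected to stay weak, with a step from compound 3 of about an at least 1.1-fold lower number from compound 3 to compound 4 (0.04 log units; that floor lies within the scatter) in this assay, that is, no clear change beyond the limit. The estimate for compound 4 in this assay is 90000 nM, between 20000 nM and 400000 nM.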

Compound 4, concentration for 50% growth inhibition: 93600 nM
The estimate for compound 4 lay 1.0-fold (0.02 log units) below the measured number; the range from low to high includes it.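

In this assay compound 3 gives > 100000 nM, which is a limit of the assay and not a number. From the compounds shown here alone, with amino in place of nitro on the aromatic carbon, para to a large group, the result at this position can be read as a number, yet the change can only be stated as a floor, an at least 1.0-fold lower number from compound 3 to compound 4 (0.02 log units; that floor lies within the scatter), and a floor within the scatter shows no clear gain from the swap, while the true size of the step stays unknown. The change does show that this single swap is enough to bring one compound of this series off the edge of what the assay can report, though only just, and the limit still holds for others: the limit of > 100000 nM in this assay, at which 2 of the 4 values shown sit.

What the compounds shown leave open is how other groups at this same place on the core of compound 4 would behave, such as an acetamide, a carboxylic acid or a hydroxyl group. Among these compounds, they also leave open whether adding a longer chain to the amino nitrogen of compound 4 would change its number, since no pair differing only at that nitrogen is available.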